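Trading Selenium for Sulfur in a Cytotoxicity Test

The compounds below may be only part of what the source reports. "The series", "measured", "known", "first", "only" and "open" are said of these compounds alone.

Of the compounds shown here, two have so far been tested in an ADME assay on Vero cells (Chlorocebus sabaeus) for cytotoxicity, read by resazurin assay, with a stated time of 72 h; a higher number here means that more compound is needed for the effect, a lower number that less compound is needed. Compound 1 (`FC(F)(F)[Se]CCOc1ccc(Oc2ccccc2)cc1`) gives > 20 uM, which is a limit of the assay and not a number. Compound 2 (`N#C[Se]CCOc1ccccc1Oc1ccccc1`) gives > 20 uM, which is also a limit and not a number. Both measured compounds therefore stand at the same point: the limit of > 20 uM in this assay, at which 2 of the 2 values shown sit.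

Compound 3 (`N#CSCCOc1ccccc1Oc1ccccc1`) has not yet been measured. It differs from compound 2 in one place: a group of 3 heavy atoms (1 carbon, 1 nitrogen, 1 sulfur; no ring) in place of a group of 3 heavy atoms (1 carbon, 1 nitrogen, 1 selenium; no ring), on a saturated chain carbon, two bonds along the chain from an oxygen on an aromatic ring. A cyanosulfanyl group replaces a group of the same size that holds selenium instead of sulfur. For the measured compounds named here, no measured pair shows this swap, so the expectation rests on compound 2 alone.

The expected change is none beyond the usual scatter: a step that the limit leaves unreadable from compound 2 to compound 3. In this assay the estimated value for compound 3 is 25 uM, with an expected range of 10 uM to 50 uM.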

Compound 3, concentration for half-maximal effect: > 20 uM
Compound 3 was reported as a limit (the forecaster's own chance of this, stated with the estimate: 75%); the middle value is on the limit's open side.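

Compound 2 and compound 3 both stand at a limit of the assay and not at a number, so no step between them can be read: the limit of > 20 uM in this assay, at which 3 of the 3 values shown sit.

The compounds shown leave open whether trading selenium for sulfur changes cytotoxicity, and at what concentration any of them would harm these cells.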